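Shortening One Propoxy Group to Methoxy

The source may hold more compounds than are shown below. What is called first, only, known or untested is meant among the compounds shown, and "the series" means these compounds.

Compound 2 (`CCCOc1cc2oc(-c3ccccc3)cc(=O)c2c(O)c1OCCC`) and compound 1 (`CCCOc1c(O)cc2oc(-c3ccccc3)cc(=O)c2c1O`) share the same core and differ in one place. In a functional assay on KB 3-1 cells (Homo sapiens), with a stated time of 1 h (a higher number here means that more compound is needed for the effect, a lower number that less compound is needed), compound 2 gives 1400 nM and compound 1 gives 2000 nM, so the two values lie within the scatter of each other and neither stands apart.

The next structure is compound 3 (`CCCOc1c(OC)cc2oc(-c3ccccc3)cc(=O)c2c1O`), which has not been measured yet. Relative to compound 2, it carries hydrogen in place of ethyl on a saturated chain carbon bound to an oxygen on an aromatic ring, which turns a propoxy into a methoxy: hydrogen in place of ethyl on a saturated chain carbon bound to an oxygen on an aromatic ring.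

For the measured compounds named here, only one measured step bears on this change, a 1.4-fold lower number from compound 1 to compound 2 (0.15 log units; within the scatter). It placed propyl in place of hydrogen on an oxygen on an aromatic ring, and it stayed within the scatter. With that single step as a guide, no change beyond the scatter is expected in this assay. The expected change is a 1.2-fold higher number from compound 2 to compound 3 (0.08 log units; within the scatter). For compound 3 the estimated value is 1700 nM, with an expected range from 700 nM to 4000 nM.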

Compound 3, half-maximal effective concentration: 1200 nM
Compound 3: the middle estimate sits 1.4-fold (0.15 log units) above what was measured; measured number inside the range.
By their numbers in this assay, from the lowest: compounds 3, 2 and 1 (each within the scatter of the next).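

With compound 3, the same oxygen on an aromatic ring has now been seen carrying hydrogen, methyl and propyl. In this assay, turning propoxy into methoxy gives a 1.2-fold lower number from compound 2 to compound 3 (0.07 log units; within the scatter) and placing methyl in place of hydrogen on that oxygen gives a 1.7-fold lower number from compound 1 to compound 3 (0.22 log units; within the scatter) as the second new step. The earlier compounds offered only the comparison of hydrogen with propyl, whereas these steps add a group of intermediate size and show that all three compounds lie within the scatter of one another, so across these three groups the identity of the group on this oxygen makes no readable difference to the number, and no measurement at hand offers an explanation for this.

The compounds shown leave open whether a chain longer than propyl, or a chain ending in an amine or a carboxylic acid, would carry the number beyond the scatter at this oxygen. They also leave open whether the same three groups would read alike in any test other than this assay, since this is the only one shown.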